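The compounds below may be only part of what the source reports. "The series", "measured", "known", "first", "only" and "open" are said of these compounds alone.

Measured so far:
compound 1, `Nc1ncnc2c1c(-c1cc3ccccc3o1)cn2[C@H]1CCN(C[C@H]2CO2)C1`, in a functional assay on JeKo-1 cells (Homo sapiens) for antiproliferative activity (on this read-out higher numbers stand for weaker inhibition and lower numbers for stronger inhibition), gives 630 nM;
compound 2, `Nc1ncnc2c1c(-c1ccc(Oc3ccccc3)cc1)cn2[C@H]1CCN(C[C@H]2CO2)C1`, in this assay gives 5080 nM.

Compound 2 stands at the higher of these two numbers, and the gap to compound 1 lies beyond the usual scatter, so compound 2 is the weaker of the pair on this read-out.

Compound 3, `Nc1ncnc2c1c(-c1ccc(Oc3ccccc3)cc1)cn2C[C@H]1CCCN1C(CO)CO`, has not yet been measured. It differs from compound 2 in one place: (1-(2-hydroxy-1-(hydroxymethyl)ethyl)pyrrolidin-2-yl)methyl in place of 1-((oxiran-2-yl)methyl)pyrrolidin-3-yl on an aromatic nitrogen. The group that leaves carries the three-membered ring; the group that enters brings two hydrogen-bond donors in its place.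

For the measured compounds named here, no measured pair shows this kind of change, so there is no direct guide to its size. The expectation for compound 3 is a modest weakening, at the edge of the scatter, giving an expected step of a 1.8-fold higher number from compound 2 to compound 3 (0.25 log units; within the scatter). Compound 3 is therefore estimated at 9000 nM, with a range from 2500 nM to 30000 nM.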

Compound 3, half-maximal inhibitory concentration: 14500 nM
The estimate for compound 3 lay 1.6-fold (0.21 log units) below the measured number, and the stated range covers the measured number.
By their numbers in this assay, from the lowest: compound 1; then compound 2; then compound 3.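

In this assay, the group on the aromatic nitrogen proves able to shift the result on its own: (1-(2-hydroxy-1-(hydroxymethyl)ethyl)pyrrolidin-2-yl)methyl in place of 1-((oxiran-2-yl)methyl)pyrrolidin-3-yl gives a 2.9-fold higher number from compound 2 to compound 3 (0.46 log units; beyond the scatter). This single step changes several things at once, removing the three-membered ring, adding two hydrogen-bond donors and altering how the five-membered ring is attached, so it cannot show which of these matters. Nothing measured here explains the weaker result.

The compounds shown leave open whether the three-membered ring itself contributes, which a plain methyl group or an acetyl group in its place on the same ring nitrogen could help to test. As far as these compounds go, it also remains open whether the same change would have a similar effect on compound 1.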